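A shorter hydroxyalkyl chain on the sulfur of compound 3

The source may report more compounds than this note shows. Statements on the series, on what has been measured and on what is new or still open speak of the compounds shown alone.

Compound 3 `CC(C)c1n[nH]c2c(NCc3ccc(-c4ccccn4)cc3)nc(SC(CO)C(C)C)nc12` gives the highest number of the three compounds in a functional assay on HT cells (Homo sapiens) for antiproliferative activity, read by fluorescence, with a stated time of 72 h (on this read-out higher numbers stand for weaker inhibition of growth and lower numbers for stronger inhibition of growth), at 980 nM. Compound 1 `CC(C)c1n[nH]c2c(NCc3ccc(-c4ccccn4)cc3)nc(SCCCN(C)C)nc12` gives 105 nM, and compound 2 `CC(C)c1n[nH]c2c(NCc3ccc(-c4ccccn4)cc3)nc(SCC(N)CN)nc12` gives 480 nM. The steps of a 9.3-fold higher number from compound 1 to compound 3 (0.97 log units; beyond the scatter) and a 2.0-fold higher number from compound 2 to compound 3 (0.31 log units; beyond the scatter) show that replacing either amine-substituted chain with the branched hydroxyalkyl group raises the number. Compound 4 `CC(C)c1n[nH]c2c(NCc3ccc(-c4ccccn4)cc3)nc(SCCCO)nc12` carries 3-hydroxypropyl in place of 1-(hydroxymethyl)-2-methylpropyl on a sulfur; the sulfur keeps its aromatic carbon neighbour. Among the measured compounds shown here, no measured step removes the branching while keeping a hydroxyl, so the nearest guide is compound 1, whose 3-(dimethylamino)propyl chain gives 105 nM. A modest gain is expected, a 1.6-fold lower number from compound 3 to compound 4 (0.21 log units; within the scatter), smaller than the step of a 9.3-fold higher number from compound 1 to compound 3 (0.97 log units; beyond the scatter). Compound 4 is estimated at 600 nM, within 250 nM to 1500 nM.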

Compound 4, concentration for 50% growth inhibition: 109 nM
The estimate for compound 4 lay 5.5-fold (0.74 log units) above the measured number, and the stated range ends above it.
By their numbers in this assay, from the lowest: compounds 1 and 4 (each within the scatter of the next); then compound 2; then compound 3.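

In this assay the 3-hydroxypropyl chain on the sulfur gives a 9.0-fold lower number from compound 3 to compound 4 (0.95 log units; beyond the scatter) and so shows that the high number of compound 3 does not come with a hydroxyl as such, since both chains carry one. Hydroxy and dimethylamino on this three-carbon chain cannot be told apart, with a 1.0-fold higher number from compound 1 to compound 4 (0.02 log units; within the scatter) and the hydroxyl chain also stands ahead of the diamine chain, with a 4.4-fold lower number from compound 2 to compound 4 (0.64 log units; beyond the scatter) and no evidence here explains these differences. The compounds shown leave open whether a carboxylic acid at the chain end, or a longer chain ending in hydroxyl, would hold this level of growth inhibition.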